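Amide-nitrogen variation on a shared core: carboxyethyl step

The source may hold more compounds than are shown below. What is called first, only, known or untested is meant among the compounds shown, and "the series" means these compounds.

Three compounds sharing one core and differing only at the amide-type nitrogen have been measured in a functional assay on PC-3 cells (Homo sapiens) for antiproliferative activity, read by MTT assay, with a stated time of 24 h; a higher number here means a weaker inhibitor, a lower number a stronger inhibitor. Compound 1 `CCn1c(C(=O)NCCN)ccc1C(CC)(CC)c1ccc(OCS(=O)(=O)c2ccccc2)c(C)c1` gives 6890 nM. Compound 2 `CCn1c(C(=O)NC2(CO)CC2)ccc1C(CC)(CC)c1ccc(OCS(=O)(=O)c2ccccc2)c(C)c1` gives 3560 nM, and compound 3 `CCn1c(C(=O)N[C@@H](CO)CCO)ccc1C(CC)(CC)c1ccc(OCS(=O)(=O)c2ccccc2)c(C)c1` gives 14100 nM. Among these three numbers compound 1 stands second highest: a 1.9-fold lower number from compound 1 to compound 2 (0.29 log units; within the scatter), while a 2.0-fold higher number from compound 1 to compound 3 (0.31 log units; beyond the scatter). Between the other two, a 4.0-fold higher number from compound 2 to compound 3 (0.60 log units; beyond the scatter).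

Compound 4 `CCn1c(C(=O)N[C@H](C)C(=O)O)ccc1C(CC)(CC)c1ccc(OCS(=O)(=O)c2ccccc2)c(C)c1` has not been measured. Relative to compound 1 the change is 1-carboxyethyl in place of 2-aminoethyl on an amide-type nitrogen. Within the data shown here, no measured step involves a 1-carboxyethyl group, so the only bearing comparisons are the two steps away from compound 1 at the same nitrogen, one within the scatter and one modest. On that basis a step of at most modest size is expected in this assay, with the direction uncertain and a slight lean toward a higher number. Compound 4 is therefore expected at 9000 nM. For compound 4 the expected range runs from 3500 nM to 25000 nM. This estimate for compound 4 amounts to an expected 1.3-fold higher number from compound 1 to compound 4 (0.12 log units; within the scatter).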

Compound 4, half-maximal inhibitory concentration: 20100 nM
Compound 4: the middle estimate sits 2.2-fold (0.35 log units) below what was measured; the range from low to high includes it.
By their numbers in this assay, from the lowest: compounds 2 and 1 (each within the scatter of the next); then compounds 3 and 4 (each within the scatter of the next).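

Among these compounds, at the amide-type nitrogen in this assay, 1-carboxyethyl in place of 2-aminoethyl gives a 2.9-fold higher number from compound 1 to compound 4 (0.46 log units; beyond the scatter) and in place of 1-(hydroxymethyl)cyclopropyl gives a 5.6-fold higher number from compound 2 to compound 4 (0.75 log units; beyond the scatter) as the first readings for a carboxylic acid at this position. Against 3-hydroxy-1-(hydroxymethyl)propyl the same group gives a 1.4-fold higher number from compound 3 to compound 4 (0.15 log units; within the scatter) and so compounds 3 and 4 form one pair at the high-number end of the four, even though their groups differ in kind. No supporting data bear on why these steps take this size.

The compounds shown hold no methyl ester or primary amide of 1-carboxyethyl, no carboxymethyl group and no opposite stereocentre. On these data alone, it therefore remains open whether the higher numbers follow the carboxylic acid, the branching methyl or the defined stereocentre.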